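This account rests on a few compounds, and the source may have more. Where it says the series, first, only, none or still open, it means among the compounds named here.

Compound 1 `Nc1nc(Cl)c2ncn(Cc3ccc(CCl)cc3)c2n1` gives 2820 nM in a functional assay on MCF7 cells (Homo sapiens) for cytotoxicity, read by sulforhodamine B assay, with a stated time of 48 h; on this read-out higher numbers stand for weaker inhibition of growth and lower numbers for stronger inhibition of growth. Compound 2 `ClCc1cccc(Cn2cnc3c(Cl)nc(Cl)nc32)c1` gives 2040 nM in this assay. Compound 3 `ClCc1ccc(Cn2cnc3c(Cl)nc(Cl)nc32)cc1` gives 1740 nM in this assay.

Compound 1 and compound 3 differ in one place, (amino in place of chloro on an aromatic carbon), and the step between them is a 1.6-fold higher number from compound 3 to compound 1 (0.21 log units; within the scatter). Compound 2 and compound 3 are built from the same atoms joined differently; the difference between the two cores is not broken down here, and their two values lie close together. Compound 4 `Nc1nc(Cl)c2ncn(Cc3cccc(CCl)c3)c2n1` has not yet been measured. It stands to compound 2 as compound 1 stands to compound 3: the change is amino in place of chloro on an aromatic carbon, the same change at the same place. Because the step of a 1.6-fold higher number from compound 3 to compound 1 (0.21 log units; within the scatter) stayed within the scatter, compound 4 is expected to show a step of a 1.6-fold higher number from compound 2 to compound 4 (0.21 log units; within the scatter) in this assay. The value expected for compound 4 is 3300 nM, with a likely range from 1500 nM to 7000 nM.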

Compound 4, concentration for 50% growth inhibition: 2390 nM
Compound 4: the middle estimate sits 1.4-fold (0.14 log units) above what was measured; low and high end bracket the measured number.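

In this assay, amino in place of chloro on an aromatic carbon gives a 1.2-fold higher number from compound 2 to compound 4 (0.07 log units; within the scatter). Set beside the earlier step on the other core, this step does not differ from it: the same change on two cores in this assay, a 1.6-fold higher number (0.21 log units; within the scatter) from compound 3 to compound 1 and a 1.2-fold higher number (0.07 log units; within the scatter) from compound 2 to compound 4, 1.4-fold (0.14 log units) apart, within the scatter of two such steps Both steps lie within the scatter, so the pair shows the change carrying over on these two cores without a readable shift, but it does not show that a step of real size would carry over, or that other cores would follow.

The compounds shown leave open whether a methylamino or methoxy group on that aromatic carbon between two ring nitrogen atoms would stay this close to the chloro compounds. They also leave open what a hydroxymethyl group in place of the chloromethyl group would do on either core.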